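Changing the amine end of compound 3

The compounds below may be only part of what the source reports. "The series", "measured", "known", "first", "only" and "open" are said of these compounds alone.

In a physicochemical assay for lipophilicity, measured as octanol-water partition, at pH 7.4 (a lower number here means a more polar compound, a higher number a more lipophilic compound), compound 1 `Cc1csc(C(=O)N[C@H]2CN(S(=O)(=O)c3ccccc3)C[C@@H]2C(=O)N[C@H]2CCCNC2)n1` gives 0.1, compound 2 `O=C(N[C@H]1CN(S(=O)(=O)c2ccccc2)C[C@@H]1C(=O)N[C@H]1CCCNC1)c1cc(-c2ccc(Cl)cc2)on1` gives 2.1 and compound 3 `O=C(N[C@H]1CN(S(=O)(=O)c2ccccc2)C[C@@H]1C(=O)N[C@H]1CCCNC1)c1cc(-c2ccccc2Cl)on1` gives 1.9. Compound 3 thus lies within the scatter of compound 2 and far above compound 1. Compound 4 `O=C(N[C@H]1CN(S(=O)(=O)c2ccccc2)C[C@@H]1C(=O)N1C[C@H]2CCNC[C@H]21)c1cc(-c2ccccc2Cl)on1` differs from compound 3 in one place: a group of 8 heavy atoms (6 carbon, 2 nitrogen; one four-membered non-aromatic ring with 1 hetero atom, one six-membered non-aromatic ring with 1 hetero atom) in place of a group of 7 heavy atoms (5 carbon, 2 nitrogen; one six-membered non-aromatic ring with 1 hetero atom), on a carbonyl carbon. Every measured step changed a different group. a number 2.00 log units higher from compound 1 to compound 2 (beyond the scatter) and a number 1.80 log units higher from compound 1 to compound 3 (beyond the scatter) were large, while a number 0.20 log units lower from compound 2 to compound 3 (within the scatter) stayed within the scatter. None of them tests this swap, so the expectation stays close to compound 3 at 1.9, with no shift beyond the scatter in this assay. The expected change is small: a number 0.10 log units higher from compound 3 to compound 4 (within the scatter). The estimate for compound 4 is 2, with an expected range of 1.5 to 2.5.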

Compound 4, distribution coefficient: 1.7
For compound 4 the middle estimate is 0.30 log units above the measured one; low and high end bracket the measured number.
By their numbers in this assay, from the lowest: compound 1; then compounds 4, 3 and 2 (each within the scatter of the next, the first and the last beyond it).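

Among these compounds, at the carbonyl carbon holding the amine end, where no earlier step made a change, this assay shows a number 0.20 log units lower from compound 3 to compound 4 (within the scatter) when the four-membered and six-membered ring group replaces (piperidin-3-yl)amino. At this position, then, the larger two-ring group with fewer hydrogen-bond donors gives a number that cannot be told apart from that of the piperidine compound. Nothing available explains this result. On these data alone, it remains open whether a carboxylic acid or an open-chain amine on this carbonyl carbon would also stay this close to compound 3. Equally open, as far as these compounds go, is whether the same swap would behave alike with the 4-methyl-1,3-thiazol-2-yl group of compound 1 in place of the chlorophenyl-bearing ring.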